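Methoxy added to the pyrazole-borne aryl ring of compound 1

The compounds below may be only part of what the source reports. "The series", "measured", "known", "first", "only" and "open" are said of these compounds alone.

Three chalcone-like pyrazoles were tested in a functional assay on SNB-19 cells (Homo sapiens) for cytotoxicity, read by sulforhodamine B assay, with a stated time of 48 h, tested at 0.1 uM; on this read-out higher numbers stand for a weaker effect at the one concentration tested and lower numbers for a stronger effect. Compound 1 `COc1ccc(-c2cc(/C=C/C(=O)c3ccc(N)cc3)[nH]n2)cc1` gives 89% there. Compound 2 `COc1cc(-c2cc(/C=C/C(=O)c3ccc(Cl)c(Cl)c3)[nH]n2)cc(OC)c1OC` gives 92%, and compound 3 `COc1ccc(C(=O)/C=C/c2cc(-c3cc(OC)c(OC)c(OC)c3)n[nH]2)cc1OC` gives 93%. All three numbers sit within the usual scatter of one another, compound 1 at one end of that narrow spread, compound 2 nearest to it and compound 3 furthest. Among the compounds with values here, the only single-point step among them, a number 1 percentage points higher from compound 2 to compound 3 (within the scatter), concerns the aryl ring on the carbonyl carbon and changes nothing beyond the scatter.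

Compound 4 `COc1ccc(-c2cc(/C=C/C(=O)c3ccc(N)cc3)[nH]n2)cc1OC` differs from compound 1 by methoxy in place of hydrogen on an aromatic carbon, the new group sitting ortho to a methoxy group and meta to a large group. Within the data shown here, no measured step touches this ring directly; the one step known, from compound 2 to compound 3, swaps substituents on the other aryl ring and is flat. Given the flat spread of compound 1, compound 2 and compound 3, no step beyond the scatter is expected in this assay. The expected step, a number 1 percentage points higher from compound 1 to compound 4 (within the scatter), stays within the scatter. Compound 4 is therefore estimated at 90%, ranging from 80% to 99%.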

Compound 4, a percentage reported as activity, at one concentration (the size of the read-out at that concentration, not a potency): 90%
The estimate for compound 4 equals the measured number at the digits printed, within the range that was stated.
By their numbers in this assay, from the lowest: compounds 1, 4, 2 and 3 (each within the scatter of the next).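

Methoxy in place of hydrogen, ortho to a methoxy group and meta to a large group, gives a number 1 percentage points higher from compound 1 to compound 4 (within the scatter) in this assay for this change on a six-membered aromatic ring of carbon only. Within the data shown here, the one earlier step touched only the aryl ring on the carbonyl carbon, so this is the first sign that the other aryl ring also takes a change without a shift beyond the scatter at the one concentration tested. No measurement available here bears on why this step is so small.

As far as these compounds go, it remains open whether a hydroxy group, a fluorine atom or a carboxylic acid at this position would move the number beyond the scatter. From the compounds shown here alone, it is also open whether this flat step would hold at a higher concentration.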